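The source may report more compounds than this note shows. Statements on the series, on what has been measured and on what is new or still open speak of the compounds shown alone.

In an ADME assay on HEL cells (Homo sapiens) for cytotoxicity, read by microscopy, with a stated time of 6 days (on this read-out lower numbers stand for higher toxicity in this test and higher numbers for lower toxicity in this test), compound 2, `CCCCCCNc1cncc(C(=O)NCc2ccccc2)n1`, reaches only the limit of the assay and gives > 100000 nM. Compound 1, `CCCCCNc1cnc(C(=O)NCc2ccccc2)cn1`, likewise stands at the limit of this assay, with > 100000 nM. Both numbers shown thus rest at the limit of > 100000 nM in this assay, at which 2 of the 2 values shown sit, so neither compound displays cytotoxicity within the range this assay can report, and nothing separates the two. Compound 3, `CCCCCNc1cncc(C(=O)NCc2ccccc2)n1`, has not yet been measured in this assay. It differs from compound 2 by a single change, (hydrogen in place of methyl on a saturated chain carbon, five bonds along the chain from a nitrogen on an aromatic ring); cut one bond further out, the same difference reads butyl to propyl. Going by the values given here, no step between two measured compounds exists to indicate how large such a change can be in this assay. The step of a number no higher from compound 2 to compound 3 (the limit leaves the size open) is expected to be none beyond the scatter. Compound 3 is estimated in this assay at 100000 nM, most probably again reported only as a limit rather than a number.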

Compound 3, minimum cytotoxic concentration: > 100000 nM
Compound 3: a limit, no number; the forecaster's own chance of this, stated with the estimate: 85%; the middle value lies on the limit itself.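

Compound 2 and compound 3 each give only a limit, not a number, in this assay, so no step can be read between them. Whether changing the chain alters cytotoxicity at all stays open, as every compound shown rests on the same limit: the limit of > 100000 nM in this assay, at which 3 of the 3 values shown sit.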